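Compound 4: a methoxy added to the inactive compound 1

The source may hold more compounds than are shown below. What is called first, only, known or untested is meant among the compounds shown, and "the series" means these compounds.

The measured compounds are few. Compound 1 has the structure `CC1(C)Cc2c(ccc(C(=O)/C=C/c3ccccc3)c2OCc2ccccc2)O1`. Compound 2 has the structure `Cc1ccc(-c2nn(-c3ccccc3)cc2/C=C/C(=O)c2ccc3c(c2OCc2ccccc2)CC(C)(C)O3)cc1`. Compound 3 has the structure `CC1(C)Cc2c(OCc3ccccc3)ccc(C(=O)/C=C/c3ccc(Cl)cc3)c2O1`.

In a functional assay on PC-3 cells (Homo sapiens) for antiproliferative activity, read by MTT assay, with a stated time of 48 h (on this read-out lower numbers stand for stronger inhibition and higher numbers for weaker inhibition), compound 1 reaches only the limit of the assay, > 100000 nM. Compound 3 also stops at a limit in this assay, > 100000 nM. Going by the values given here, compound 2 is the one that gives a number in this assay, 24200 nM. Compound 1 therefore stands at the top of what the assay can report, together with compound 3, as the limit of > 100000 nM in this assay, at which 2 of the 3 values shown sit, shows; only compound 2 lies inside the measurable range.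

Compound 4, with the structure `COc1ccc(/C=C/C(=O)c2ccc3c(c2OCc2ccccc2)CC(C)(C)O3)cc1`, is not yet measured. It differs from compound 1 by methoxy in place of hydrogen on an aromatic carbon. Among the compounds with values here, no step between measured compounds matches this change. Since compound 1 sits at the limit of this assay, and compound 3, which carries a different small group on the same ring, sits there too, no step beyond the scatter is expected in this assay, and compound 4 is expected to remain at or near that limit.

Compound 4 is estimated at 100000 nM in this assay. The expected range for compound 4 runs from 30000 nM to 300000 nM. The step expected is a number no higher from compound 1 to compound 4 (the limit leaves the size open).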

Compound 4, half-maximal inhibitory concentration: 48900 nM
For compound 4 the middle estimate is 2.0-fold (0.31 log units) above the measured one, and the stated range covers the measured number.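

In this assay, methoxy in place of hydrogen on an aromatic carbon, para to a large group, gives an at least 2.0-fold lower number from compound 1 to compound 4 (0.31 log units; beyond the scatter), the only step among the compounds shown that can be read. This shows that the position is not silent: the change from phenyl to 4-methoxyphenyl on the core of compound 1 alone is enough to bring a compound into the measurable range, and compound 4 gives 48900 nM, which remains a weak value on this read-out. The value of compound 1, > 100000 nM, is a limit and not a number, so the full size of the step stays open: the limit of > 100000 nM in this assay, at which 2 of the 4 values shown sit.

The compounds shown leave open whether the oxygen of the methoxy matters here or any small group on this carbon would do the same, which a hydroxyl, a methyl or a fluorine at this place would begin to tell, and whether a longer chain such as ethoxy would go further. They also leave open whether the same change would give a step on another core, and they say nothing about why the number moves.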